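The source may report more compounds than this note shows. Statements on the series, on what has been measured and on what is new or still open speak of the compounds shown alone.

Three compounds share one core and were tested in an ADME assay on the whole organism for cytotoxicity, with Artemia salina as the target, with a stated time of 24 h; a lower number here means that less compound is needed, a higher number that more compound is needed for the effect. Compound 1 `COc1cccc(/C=C/C(=O)c2ccccc2NC(=O)NS(=O)(=O)c2ccc(C)cc2)c1` gives 23.2 ug/mL in this assay, compound 2 `COc1ccc(/C=C/C(=O)c2ccccc2NC(=O)NS(=O)(=O)c2ccc(C)cc2)cc1OC` gives 12.9 ug/mL, and compound 3 `Cc1ccc(S(=O)(=O)NC(=O)Nc2ccccc2C(=O)/C=C/c2cccc(O)c2)cc1` gives 39.3 ug/mL. Compound 2 has the lowest of the three numbers; the nearest belongs to compound 1 and the furthest to compound 3, since a 1.8-fold lower number from compound 1 to compound 2 (0.25 log units; within the scatter), whereas a 3.0-fold higher number from compound 2 to compound 3 (0.48 log units; beyond the scatter). Between the other two, a 1.7-fold higher number from compound 1 to compound 3 (0.23 log units; within the scatter).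

Compound 4 `Cc1ccc(S(=O)(=O)NC(=O)Nc2ccccc2C(=O)/C=C/c2ccccc2Cl)cc1` has not yet been measured in this assay. It differs from compound 2 in one place: 2-chlorophenyl in place of 3,4-dimethoxyphenyl on a double-bonded chain carbon bound to a double-bonded chain carbon. The step that bears most directly on this change is the one at the same place, where a 3.0-fold higher number from compound 2 to compound 3 (0.48 log units; beyond the scatter): replacing the 3,4-dimethoxyphenyl raised the number modestly. The change to compound 4 also removes the 3,4-dimethoxyphenyl, so a modest rise of similar size is expected, and a 2.0-fold higher number from compound 2 to compound 4 (0.30 log units; within the scatter) is the step this estimate implies. Compound 4 is therefore expected to give about 26 ug/mL in this assay, with a range from 12 ug/mL to 55 ug/mL.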

Compound 4, concentration for half-maximal effect: 12.8 ug/mL
Beside the measured number, compound 4's estimate is 2.0-fold (0.31 log units) above it; the range from low to high includes it.
By their numbers in this assay, from the lowest: compounds 4, 2, 1 and 3 (each within the scatter of the next, the first and the last beyond it).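

At this place on the double-bonded chain carbon, the earlier rise on leaving 3,4-dimethoxyphenyl does not hold for every replacement, since in this assay 2-chlorophenyl, which carries no oxygen, shows no separation from it (a 1.0-fold lower number from compound 2 to compound 4 (0.00 log units; within the scatter)). The compounds now form a clearer picture around compound 3, which is set apart from compound 4 (a 3.1-fold lower number from compound 3 to compound 4 (0.49 log units; beyond the scatter)) as it is from compound 2, though not from compound 1. Compound 4 and compound 1 remain together (a 1.8-fold lower number from compound 1 to compound 4 (0.26 log units; within the scatter)), so 2-chlorophenyl, 3-methoxyphenyl and 3,4-dimethoxyphenyl cannot be ordered here. Going by these compounds, it stays open whether the chlorine matters at all, and how an unsubstituted phenyl, an aminophenyl or a carboxyphenyl would behave at this place. Nothing available here explains why these numbers fall as they do.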